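The source may hold more compounds than are shown below. What is called first, only, known or untested is meant among the compounds shown, and "the series" means these compounds.

Measured compounds:
- Compound 1 `NS(=O)(=O)c1cc(-c2nnc(CN3CCC(Cc4ccccc4)CC3)o2)c(Cl)cc1SCc1ccccc1`: in a functional assay on HeLa cells (Homo sapiens) for cytotoxicity, read by MTT assay, with a stated time of 72 h (a lower number here means a stronger inhibitor, a higher number a weaker inhibitor), compound 1 gives 16000 nM.
- Compound 2 `CCOC(=O)c1cn(Cc2nnc(-c3cc(S(N)(=O)=O)c(SCc4ccccc4)cc3Cl)o2)nn1`: in this assay compound 2 gives 122000 nM.

Of these two numbers, compound 2 holds the highest, so it is the weaker of the pair in this assay; the gap to compound 1 is beyond the usual scatter of the measurement, and the two compounds differ in more than one place, so that gap is reported here only as what the two values show.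

Compound 3 `NS(=O)(=O)c1cc(-c2nnc(/C=C/c3ccc(Cl)cc3)o2)c(Cl)cc1SCc1ccccc1` has not yet been measured. Compared with compound 2, the change is this: 2-(4-chlorophenyl)ethenyl in place of (4-(ethoxycarbonyl)-1H-1,2,3-triazol-1-yl)methyl on an aromatic carbon. The group that leaves is the (4-(ethoxycarbonyl)-1H-1,2,3-triazol-1-yl)methyl; the group that enters is the 2-(4-chlorophenyl)ethenyl, placed on an aromatic carbon of the five-membered aromatic ring with 2 nitrogen and 1 oxygen.

Among the compounds with values here, no measured pair shows this exact change, so the expectation rests only on compound 1 and compound 2. The step of a 6.1-fold lower number from compound 2 to compound 3 (0.79 log units; beyond the scatter) is estimated to go toward a lower number, of moderate size, beyond the scatter. Compound 3 is expected to give about 20000 nM in this assay, within a range from 5000 nM to 80000 nM.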

Compound 3, half-maximal inhibitory concentration: 40000 nM
Estimate against measurement, compound 3: 2.0-fold (0.30 log units) below; low and high end bracket the measured number.
By their numbers in this assay, from the lowest: compound 1; then compound 3; then compound 2.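

In this assay, within the data shown here, the 2-(4-chlorophenyl)ethenyl in place of the (4-(ethoxycarbonyl)-1H-1,2,3-triazol-1-yl)methyl gives a 3.1-fold lower number from compound 2 to compound 3 (0.48 log units; beyond the scatter), the first change at this aromatic carbon that can be read on its own. The earlier pair differed in more than one place, whereas this step swaps a single group, one with a five-membered aromatic ring with 3 hetero atoms and 5 hydrogen-bond acceptors, for one with a six-membered aromatic ring of carbon only and 0 hydrogen-bond acceptors. The lower number still does not reach that of compound 1: compound 3 gives 40000 nM, while compound 1 gives 16000 nM. No measurement at hand gives a reason for this step.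

The ethenyl link and the 4-chlorophenyl ring enter together, so the compounds shown cannot tell which part goes with the lower number. Also open, as far as these compounds go, is how a carboxylic acid in place of the ethoxycarbonyl, or a 2-phenylethyl chain without the double bond and the chlorine, would stand at this carbon.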